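Series notes: chlorophenyl-triazole sulfonamides against gastric carcinoma cells

The source may report more compounds than this note shows. Statements on the series, on what has been measured and on what is new or still open speak of the compounds shown alone.

Measured compounds:
compound 1 `O=c1[nH]cc(S(=O)(=O)Nc2cccc(-c3cn(-c4cccc(Cl)c4)nn3)c2)c(=O)[nH]1` — 3950 nM
compound 2 `O=c1[nH]cc(S(=O)(=O)Nc2cccc(-c3cn(-c4ccc(Cl)cc4)nn3)c2)c(=O)[nH]1` — 2160 nM
compound 3 `O=c1[nH]cc(S(=O)(=O)Nc2ccc(-c3cn(-c4cccc(Cl)c4)nn3)cc2)c(=O)[nH]1` — 2460 nM

All three were tested in a functional assay on SGC-7901 cells (Homo sapiens) for antiproliferative activity, read by MTT assay, with a stated time of 24 h; a higher number here means a weaker inhibitor, a lower number a stronger inhibitor. Compound 1 and compound 2 share one core and differ by 4-chlorophenyl in place of 3-chlorophenyl on an aromatic nitrogen; in this assay that change gave a 1.8-fold lower number from compound 1 to compound 2 (0.26 log units; within the scatter). Compound 3 carries a different core; the difference between the core of compound 1 and the core of compound 3 is not broken down here, and the two values show compound 3 and compound 1 lying close together.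

Compound 4 `O=c1[nH]cc(S(=O)(=O)Nc2ccc(-c3cn(-c4ccc(Cl)cc4)nn3)cc2)c(=O)[nH]1` has not yet been measured. It differs from compound 3 by 4-chlorophenyl in place of 3-chlorophenyl on an aromatic nitrogen, the same change, at a place described in the same words, as that from compound 1 to compound 2. Going by the values given here, on that basis a step of about the same size is expected, estimated as a 1.6-fold lower number from compound 3 to compound 4 (0.21 log units; within the scatter), resting on the single earlier step of a 1.8-fold lower number from compound 1 to compound 2 (0.26 log units; within the scatter) and on the value of compound 3, 2460 nM. Among the compounds with values here, only one such step is known, and it lies within the scatter. The expectation is therefore loose. For compound 4 in this assay the estimate is 1500 nM, with a range from 700 nM to 3500 nM.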

Compound 4, half-maximal inhibitory concentration: 1830 nM
Compound 4: middle estimate off by 1.2-fold (0.09 log units), on the low side; low and high end bracket the measured number.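

In this assay the exchange of 3-chlorophenyl for 4-chlorophenyl gives a 1.3-fold lower number from compound 3 to compound 4 (0.13 log units; within the scatter), and this step agrees with the earlier one within what repeated measurements allow: the same change on two cores in this assay, a 1.8-fold lower number (0.26 log units; within the scatter) from compound 1 to compound 2 and a 1.3-fold lower number (0.13 log units; within the scatter) from compound 3 to compound 4, 1.4-fold (0.13 log units) apart, within the scatter of two such steps. The change therefore carries from the core of compound 1 to the core of compound 3 with no sign of a different outcome on the second core. Neither step lies beyond the scatter, however, so the pair does not show that the change has a real effect on either core, and two cores say nothing about how it would behave on a third.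

The compounds shown leave open what happens when the chlorine gives way to another group, such as hydrogen, methoxy, an amine or a carboxylic acid. Also open, from the compounds shown here alone, is whether a longer chain in place of the chlorophenyl on the aromatic nitrogen would give a step beyond the scatter in this assay.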